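The compounds below may be only part of what the source reports. "The series", "measured", "known", "first", "only" and "open" are said of these compounds alone.

Measured so far in a functional assay on HFL1 cells for antagonist activity at sphingosine 1-phosphate receptor 2 (Homo sapiens), read by ELISA, with a stated time of 24 h, in the presence of a further agent that is not named here; on this read-out higher numbers stand for weaker inhibition and lower numbers for stronger inhibition:
- compound 1 `O=C(O)Cn1nc(Cn2cc3cc(OCC4CC4)c(Cl)cc3n2)c2ccccc2c1=O`: 647 nM
- compound 2 `COC(C(=O)O)c1nn(Cc2cn3cc(OCC4CC4)c(Cl)cc3n2)c2ccccc2c1=O`: 217 nM
- compound 3 `C[C@H](C(=O)O)n1nc(Cn2cc3cc(OCC4CC4)c(Cl)cc3n2)c2ccccc2c1=O`: 197 nM

Compound 1 gives the highest number of the three; compound 2 and compound 3 both sit lower, each beyond the scatter. Within the data shown here, the one single-point step on record, a 3.3-fold lower number from compound 1 to compound 3 (0.52 log units; beyond the scatter), concerns the chain carbon bound to the aromatic nitrogen and the carbonyl carbon, not the ether side.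

Compound 4 `CCOc1cc2cn(Cc3nn(CC(=O)O)c(=O)c4ccccc34)nc2cc1Cl` differs from compound 1 by methyl in place of cyclopropyl on a saturated chain carbon bound to an oxygen on an aromatic ring, that is, cyclopropylmethoxy to ethoxy. Among the measured compounds shown here, no measured pair varies this position, so nothing on record bears on the step directly. With no guide, the number for compound 4 is expected to stay near that of compound 1, a 1.2-fold higher number from compound 1 to compound 4 (0.09 log units; within the scatter), with a wide range. Compound 4 is estimated at 800 nM (range 250 nM to 2600 nM).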

Compound 4, half-maximal inhibitory concentration: 1620 nM
Estimate against measurement, compound 4: 2.0-fold (0.31 log units) below; measured number inside the range.
By their numbers in this assay, from the lowest: compounds 3 and 2 (each within the scatter of the next); then compound 1; then compound 4.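

Among these compounds, this is the first reading on the ether side of the series: in this assay, cyclopropylmethoxy to ethoxy gives a 2.5-fold higher number from compound 1 to compound 4 (0.40 log units; beyond the scatter), so this position responds to the change, and the ethoxy compound inhibits more weakly. The earlier compounds shown here showed changes only on the acid side. Nothing on record gives a reason for this step.

The compounds shown leave open whether the loss of the ring or the loss of carbon count matters, which a propyl or cyclobutylmethyl ether could separate. From the compounds shown here alone, whether the step carries over to the methyl-bearing acid chain of compound 3 also remains open.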